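One Methyl-to-Chloro Swap Starting from Compound 1

A few compounds are considered here, and "the series" means these few. Any claim that something is new, unique, unknown or untested is made for them only; others in the source may bear on it.

Measured so far in a functional assay on MCF7 cells (Homo sapiens) for inhibition, read by CCK-8 assay, with a stated time of 48 h; on this read-out higher numbers stand for weaker inhibition and lower numbers for stronger inhibition:
- compound 1 `Cc1ccc(-c2nn(-c3ccccc3)cc2C(=O)NC(=S)Nc2ccc(Cl)cc2)cc1` gives 6210 nM
- compound 2 `Cc1ccc(NC(=S)NC(=O)c2cn(-c3ccccc3)nc2-c2ccc(C)cc2)cc1` gives 5660 nM
- compound 3 `O=C(NC(=S)Nc1ccc(F)cc1)c1cn(-c2ccccc2)nc1-c1ccccc1` gives 6820 nM

Compound 1 holds the middle of these three numbers, and both compound 2 and compound 3 lie within the usual scatter of it, so the three cannot be told apart on this read-out.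

Compound 4 `O=C(NC(=S)Nc1ccc(Cl)cc1)c1cn(-c2ccccc2)nc1-c1ccc(Cl)cc1` differs from compound 1 by chloro in place of methyl on an aromatic carbon. Among the compounds with values here, the only measured step, a 1.1-fold lower number from compound 1 to compound 2 (0.04 log units; within the scatter), is the same pair of groups exchanged in the opposite direction on the other aromatic ring, and it did not move the number beyond the scatter. Compound 3, which carries fluoro in place of chloro on that other ring and lacks the methyl, also gives a number within the scatter of compound 1. Within the data shown here, nothing measured so far shows that swapping a small group on either outer ring shifts this assay. The step from compound 1 to compound 4 is therefore expected to be a 1.0-fold lower number from compound 1 to compound 4 (0.00 log units; within the scatter), no change beyond the scatter. Compound 4 is estimated at 6200 nM, with a range from 3000 nM to 13000 nM.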

Compound 4, half-maximal inhibitory concentration: 5360 nM
Compound 4: the middle estimate sits 1.2-fold (0.06 log units) above what was measured; the measured number falls inside the stated range.
By their numbers in this assay, from the lowest: compounds 4, 2, 1 and 3 (each within the scatter of the next).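

Exchanging 4-methylphenyl for 4-chlorophenyl in this assay gives a 1.2-fold lower number from compound 1 to compound 4 (0.06 log units; within the scatter), so methyl and chloro cannot be told apart at this place on the ring. The earlier step, a 1.1-fold lower number from compound 1 to compound 2 (0.04 log units; within the scatter), exchanged the same two groups on the other outer ring, so this pair has now been read on both rings, with neither step beyond the scatter. No supporting measurement bears on this result.

From the compounds shown here alone, the outer-ring groups compared here are limited to methyl, chloro and fluoro, so it remains open whether an amine, a carboxylic acid or a longer alkyl chain at this place would move the number beyond the scatter. The compounds shown also share one core, so they leave open how much any change to that core would matter.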